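The source may hold more compounds than are shown below. What is called first, only, known or untested is meant among the compounds shown, and "the series" means these compounds.

Working notes on the series. The shared core is that of compound 1 `Cn1cncc1C(OCc1ccc(C#N)cc1C#Cc1ccccn1)c1ccc(C#N)cc1`, and the three measured compounds vary one group on an aromatic carbon. In a functional assay on NIH3T3 cells (Mus musculus) (on this read-out lower numbers stand for an effect already at smaller amounts and higher numbers for an effect only at larger amounts of compound), compound 1 gives only a limit, > 0.1 nM. Compound 2 `Cn1cncc1C(OCc1ccc(C#N)cc1/C=C/c1ccc([N+](=O)[O-])cc1)c1ccc(C#N)cc1` carries a 2-(4-nitrophenyl)ethenyl on that aromatic carbon and in this assay compound 2 gives 2.24 nM. Compound 3 `Cn1cncc1C(OCc1ccc(C#N)cc1-c1ccc(C#N)cc1)c1ccc(C#N)cc1` carries a 4-cyanophenyl on the aromatic carbon; in this assay compound 3 sits at a limit as well, < 0.1 nM. The steps read a step that the limit leaves unreadable from compound 1 to compound 2, a number no higher from compound 1 to compound 3 (the limit leaves the size open) and an at least 22-fold lower number from compound 2 to compound 3 (1.35 log units; beyond the scatter); the limits the limit of < 0.1 nM in this assay, at which 1 of the 3 values shown sits, and the limit of > 0.1 nM in this assay, at which 1 of the 3 values shown sits, leave the first two without a size, while the third is clearly large.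

Compound 4 `Cn1cncc1C(OCc1ccc(C#N)cc1C#Cc1ccc(C#N)cc1)c1ccc(C#N)cc1` differs from compound 1 by 4-cyanophenyl in place of pyridin-2-yl on a triple-bonded carbon, so the 4-cyanophenyl of compound 3 is kept, held out on the ethynyl of compound 1. For the measured compounds named here, the step bearing on it is the one from compound 1 to compound 3, which shows a number no higher. The step is therefore expected to be a step that the limit leaves unreadable from compound 1 to compound 4, none beyond the scatter or downward. For compound 4 the estimate in this assay is 0.3 nM, within 0.05 nM to 2 nM.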

Compound 4, half-maximal effective concentration: 11.6 nM
For compound 4 the middle estimate is 39-fold (1.59 log units) below the measured one, outside the stated range (above it).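

Setting an ethynyl between the aromatic carbon and the 4-cyanophenyl changes the read-out in this assay sharply, a point the earlier compounds could not show: an at least 110-fold higher number from compound 3 to compound 4 (2.06 log units; beyond the scatter). Among the two compounds with measured numbers, the 2-(4-cyanophenyl)ethynyl group also stands apart from the 2-(4-nitrophenyl)ethenyl group, with a 5.2-fold higher number from compound 2 to compound 4 (0.71 log units; beyond the scatter), so the two extended groups are not equivalent at this position. The step from pyridin-2-yl to 4-cyanophenyl on the triple-bonded carbon cannot be read, because compound 1 rests on a limit: the limit of > 0.1 nM in this assay, at which 1 of the 4 values shown sits.

As far as these compounds go, the step between compound 2 and compound 4 changes the two-carbon link and the ring substituent together, so their separate contributions stay open. Also open, from the compounds shown here alone, is how a carboxylic acid or an amine at the end of the ethynyl group would read out in this assay.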